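Amide series: oxazole-aryl change from compound 3 to compound 4

A few compounds are considered here, and "the series" means these few. Any claim that something is new, unique, unknown or untested is made for them only; others in the source may bear on it.

Compound 1 `Cc1nc(-c2ccccc2F)c(C(=O)N2CCN(c3cc(Cl)cc(Cl)c3)CC2)o1` and compound 2 `COc1cccc(N2CCN(C(=O)c3oc(C)nc3-c3ccccc3F)CC2)c1` share a core and differ only in the group on the amine nitrogen in a ring. In a functional assay on HL-60 cells (Homo sapiens) for inhibition, read by MTT assay, with a stated time of 72 h (on this read-out higher numbers stand for weaker inhibition and lower numbers for stronger inhibition), compound 1 gives 60.2 nM, and compound 2 gives 56.1 nM; the step of a 1.1-fold lower number from compound 1 to compound 2 (0.03 log units; within the scatter) shows that 3-methoxyphenyl in place of 3,5-dichlorophenyl at that position leaves the read-out unchanged. Compound 3 `COc1cccc(-c2nc(C)oc2C(=O)N2CCN(c3cccc(Cl)c3)CC2)c1` carries 3-methoxyphenyl on the core instead and is reported as "not active" (no number reported) in this assay, with no number given, so it stands apart from compounds 1 and 2, which both return numbers.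

Compound 4 `Cc1nc(-c2ccccc2)c(C(=O)N2CCN(c3cccc(Cl)c3)CC2)o1` is reached from compound 3 by hydrogen in place of methoxy on an aromatic carbon. Going by the values given here, no measured step touches this position; the one measured step concerns the other ring and is within the scatter, so it gives no guide to size or direction here. Among the compounds with values here, the only anchor is that compound 3 gave no number while compounds 1 and 2 did. Compound 4 is therefore expected to land between those outcomes, near 300 nM, with a wide range from 40 nM to 5000 nM, and a real chance that this assay again reports no number.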

Compound 4, half-maximal inhibitory concentration: 39.2 nM
Compound 4: middle estimate off by 7.7-fold (0.88 log units), on the high side; measured number outside the range, below it.
By their numbers in this assay, from the lowest: compounds 4, 2 and 1 (each within the scatter of the next).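

Going by these compounds alone, compound 3 has no number in this assay, so no step to compound 4, at 39.2 nM, can be read. Nothing shown bears on the cause of this result. The compounds shown leave open how the change from 3-methoxyphenyl to phenyl behaves with other groups on the amine nitrogen.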